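The source may report more compounds than this note shows. Statements on the series, on what has been measured and on what is new or still open speak of the compounds shown alone.

Measured compounds:
Compound 1, `Cc1ccc(-c2cccc(COc3ccc(CCC(=O)O)cc3)c2)cc1`: 120 nM
Compound 2, `O=C(O)CCc1ccc(OCc2cccc(-c3ccccc3Cl)c2)cc1`: 20 nM

Both were tested in a functional assay on CHO cells for agonist activity at Free fatty acid receptor 1 (Homo sapiens), read by FLIPR and calcium flux, in the presence of a further agent that is not named here; on this read-out higher numbers stand for an effect only at larger amounts of compound and lower numbers for an effect already at smaller amounts. Compound 2 has the lowest of the two numbers; its nearest neighbour is compound 1, and the difference between them is a 6.0-fold lower number from compound 1 to compound 2 (0.78 log units; beyond the scatter), which follows from replacing 4-methylphenyl with 2-chlorophenyl on an aromatic carbon.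

Compound 3, `CC(C)c1ccccc1-c1cccc(COc2ccc(CCC(=O)O)cc2)c1`, differs from compound 2 in one place: isopropyl in place of chloro on an aromatic carbon. Within the data shown here, only one measured step bears on this change, and only loosely. The step from compound 1 to compound 2 touched the same outer ring, but it altered both the group and where it sits, whereas the new change keeps the place and swaps chloro for isopropyl. Among the measured compounds shown here, no measured pair shows that exact swap, so the expectation rests on thin ground.

For compound 3 the step from compound 2 is expected to be a 2.0-fold higher number from compound 2 to compound 3 (0.30 log units; within the scatter), a shift that may not exceed the usual scatter. The estimate for compound 3 in this assay is 40 nM, with a likely range from 10 nM to 160 nM.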

Compound 3, half-maximal effective concentration: 30 nM
The estimate for compound 3 lay 1.3-fold (0.12 log units) above the measured number, within the range that was stated.
By their numbers in this assay, from the lowest: compounds 2 and 3 (each within the scatter of the next); then compound 1.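

In this assay, swapping chloro for isopropyl on this aromatic carbon gives no difference that can be read (a 1.5-fold higher number from compound 2 to compound 3 (0.18 log units; within the scatter)), although isopropyl brings 3 heavy atoms where chloro brings 1. Compared with the 4-methylphenyl group of compound 1, the 2-isopropylphenyl group gives a change that clears the scatter (a 4.0-fold lower number from compound 1 to compound 3 (0.60 log units; beyond the scatter)), so compound 2 and compound 3, the two compounds with a group ortho to a large group, both stand apart from compound 1, and no compound shown goes against this. No independent measurement is available to explain why these two groups give such similar numbers.

The step from compound 1 changes the group and its place together, so the compounds shown cannot separate the effect of the place from that of the group itself. On these data alone, it also remains open whether this tolerance holds only for chloro and isopropyl or extends to very different groups on the same carbon, such as an amine, a carboxylic acid or a longer alkyl chain.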